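From a Bromophenyl Amide to a Cyanophenyl Amide

A few compounds are considered here, and "the series" means these few. Any claim that something is new, unique, unknown or untested is made for them only; others in the source may bear on it.

Measured in an assay on cells for agonist activity at ecdysone receptor (Bombyx mori), read by a luciferase reporter, with a stated time of 24 h; on this read-out higher numbers stand for an effect only at larger amounts of compound and lower numbers for an effect already at smaller amounts:
compound 1 `CC(C)(C)N(NC(=O)c1ccccc1)C(=O)c1ccccc1C(F)(F)F` gives 631 nM
compound 2 `COc1ccccc1C(=O)N(NC(=O)c1ccccc1)C(C)(C)C` gives 525 nM
compound 3 `CC(C)(C)N(NC(=O)c1cccc(Br)c1)C(=O)c1ccccc1Cl` gives 191 nM

Compound 3 stands lowest of the three numbers, and its gaps to compound 2 and to compound 1 both lie beyond the scatter, so it is the most potent of the measured set. Compound 4 `CC(C)(C)N(NC(=O)c1ccc(C#N)cc1)C(=O)c1ccccc1Cl` differs from it in one place: 4-cyanophenyl in place of 3-bromophenyl on a carbonyl carbon. Among the compounds with values here, the only measured single-point step, a 1.2-fold lower number from compound 1 to compound 2 (0.08 log units; within the scatter), concerns the group on the other carbonyl carbon and lies within the scatter, so it does not speak to this change. Within the data shown here, no measured step touches the group that is exchanged here. In this assay compound 4 is therefore expected to give a number somewhat higher than compound 3, a step of a 2.1-fold higher number from compound 3 to compound 4 (0.32 log units; beyond the scatter), with wide uncertainty; the estimate for compound 4 is 400 nM, between 120 nM and 1500 nM.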

Compound 4, half-maximal effective concentration: 603 nM
For compound 4 the middle estimate is 1.5-fold (0.18 log units) below the measured one, within the range that was stated.
By their numbers in this assay, from the lowest: compound 3; then compounds 2, 4 and 1 (each within the scatter of the next).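

In this assay, this is the first single change among the compounds shown whose step lies beyond the scatter (a 3.2-fold higher number from compound 3 to compound 4 (0.50 log units; beyond the scatter)). The group on this carbonyl carbon therefore matters, and 4-cyanophenyl, despite its hydrogen-bond acceptor, gives no lower number than 3-bromophenyl. No measurement at hand bears on why the number rises.

The change exchanges the substituent and its ring position together, so a 4-bromophenyl or a 3-cyanophenyl would be needed to separate the two. As far as these compounds go, how an amine or a carboxylic acid on this ring would read also stays open.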